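Methyl for Hydrogen on a Ring Carbon: Compound 4

The compounds below may be only part of what the source reports. "The series", "measured", "known", "first", "only" and "open" are said of these compounds alone.

Measured in a functional assay on CHO cells for agonist activity at sphingosine 1-phosphate receptor 2 (Homo sapiens), read by fluorescence and calcium flux, with a stated time of 3 min; on this read-out higher numbers stand for weaker inhibition and lower numbers for stronger inhibition:
compound 1 `CCOc1cc(NC(=O)NCc2cc(C)c(-c3cn(C)nc3C(F)(F)F)nn2)cc(C#N)n1` gives 5500 nM;
compound 2 `Cc1cc(CNC(=O)Nc2cc(OCCO)nc(C(F)(F)F)c2)nnc1-c1cn(C)nc1C(F)(F)F` gives 4000 nM;
compound 3 `CCOc1nc(C#N)cc(NC(=O)NCc2cc(C)c(-c3cn(C)nc3C(F)(F)F)nn2)c1C` gives 5500 nM.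

Compound 4 `Cc1cc(CNC(=O)Nc2cc(C(F)(F)F)nc(OCCO)c2C)nnc1-c1cn(C)nc1C(F)(F)F` is not yet measured. It differs from compound 2 by methyl in place of hydrogen on an aromatic carbon. The same kind of change has been made once before, from compound 1 to compound 3: methyl in place of hydrogen on an aromatic carbon. There the step was no change at the digits printed from compound 1 to compound 3 (within the scatter). The two places are not identical: in compound 1 the carbon is ortho to an ethoxy group and para to a cyano group, whereas in compound 2 it is ortho to a 2-hydroxyethoxy group and para to a trifluoromethyl group. The difference between the cores of compound 1 and compound 2 is not broken down here; the three measured values all lie within the scatter of each other in this assay. Because the earlier step was no change at the digits printed from compound 1 to compound 3 (within the scatter), compound 4 is expected to sit close to compound 2, with an estimated step of a 1.1-fold higher number from compound 2 to compound 4 (0.02 log units; within the scatter). The estimate for compound 4 in this assay is 4200 nM, between 2000 nM and 9000 nM.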

Compound 4, half-maximal inhibitory concentration: 4400 nM
Compound 4: middle estimate off by 1.0-fold (0.02 log units), on the low side; the measured number falls inside the stated range.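

In this assay methyl in place of hydrogen on an aromatic carbon gave a 1.1-fold higher number from compound 2 to compound 4 (0.04 log units; within the scatter) and this can be set beside the earlier step on the other core: the same change on two cores in this assay, no change at the digits printed (within the scatter) from compound 1 to compound 3 and a 1.1-fold higher number (0.04 log units; within the scatter) from compound 2 to compound 4, 1.1-fold (0.04 log units) apart, within the scatter of two such steps. Across these two cores the change therefore carried over as a step within the scatter, here with the methyl ortho to a 2-hydroxyethoxy group and para to a trifluoromethyl group. Within the data shown here, this does not show that the change would behave alike on other cores or at other ring carbons, as it rests on only two pairs.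

The compounds shown leave open whether an ethyl group or an amine on this ring carbon would give a step beyond the scatter. They also leave open whether methyl would behave alike on a core bearing a carboxylic acid.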